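A few compounds are considered here, and "the series" means these few. Any claim that something is new, unique, unknown or untested is made for them only; others in the source may bear on it.

Measured in a functional assay on the whole organism (strain Wistar) for inhibition, with Rattus norvegicus as the target, read by paw edema, with stated times of 60 min and 24 h, at a dose of 100 mg/kg by the oral route; on this read-out lower numbers stand for less inhibition and higher numbers for more inhibition at the one dose given (going by the name of the read-out):
compound 1 `COc1cc2c(cc1OC)C(CC(=O)N(C)C)CC2`, 23.3%
compound 2 `COc1cc2c(cc1OC)C(CC(=O)NC1CCCCC1)CC2`, 53.3%
compound 3 `COc1cc2c(cc1OC)C(CC(=O)N1CCNCC1)CC2`, 65%

Compound 1 stands lowest of the three numbers, with compound 2 nearest and compound 3 furthest above it. Compound 4 `COc1cc2c(cc1OC)C(CC(=O)NCCO)CC2` differs from compound 1 in one place: (2-hydroxyethyl)amino in place of dimethylamino on a carbonyl carbon. Two measured steps leave dimethylamino at the same carbonyl carbon: a number 30 percentage points higher from compound 1 to compound 2 (beyond the scatter) and a number 41.7 percentage points higher from compound 1 to compound 3 (beyond the scatter), both upward and both beyond the scatter. The third step, a number 11.7 percentage points higher from compound 2 to compound 3 (beyond the scatter), does not touch compound 1. On these two steps an increase beyond the scatter is expected for compound 4 in this assay, smaller than the largest seen, about a number 21.7 percentage points higher from compound 1 to compound 4 (beyond the scatter). Compound 4 is therefore estimated at 45%, with a range from 25% to 65%.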

Compound 4, a percentage reported as inhibition, in the whole organism at one dose (the size of the read-out at that dose, not a potency): 13.3%
For compound 4 the middle estimate is 31.7 percentage points above the measured one; the whole stated range lies above it.
By their numbers in this assay, from the lowest: compounds 4 and 1 (each within the scatter of the next); then compound 2; then compound 3.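

In this assay the carbonyl carbon does not reward every replacement of dimethylamino: with (2-hydroxyethyl)amino the result is a number 10 percentage points lower from compound 1 to compound 4 (within the scatter) and not the rise seen with cyclohexylamino or piperazin-1-yl. The new amide also stands far from the other two, with a number 51.7 percentage points lower from compound 3 to compound 4 (beyond the scatter) and a number 40 percentage points lower from compound 2 to compound 4 (beyond the scatter) both large, so the group entering at this position can decide the outcome. The compounds shown leave open how a longer hydroxyalkyl chain, methoxyethylamino or morpholin-4-yl would read here. No evidence at hand explains why (2-hydroxyethyl)amino stands so far under cyclohexylamino and piperazin-1-yl.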